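Fluoro for nitro on the aryl ketone of compound 2

The source may report more compounds than this note shows. Statements on the series, on what has been measured and on what is new or still open speak of the compounds shown alone.

Compound 1 `Cn1cc(C(=O)c2ccc(Cl)cc2)cc1/C=C/C(=O)NO`: 1450 nM
Compound 2 `Cn1cc(C(=O)c2ccc([N+](=O)[O-])cc2)cc1/C=C/C(=O)NO`: 2340 nM

In an assay on isolated protein with histone deacetylase HD2 (Zea mays) as the target (on this read-out lower numbers stand for stronger inhibition and higher numbers for weaker inhibition), compound 2 gives the highest of the two numbers; its nearest neighbour is compound 1, and the step of a 1.6-fold higher number from compound 1 to compound 2 (0.21 log units; within the scatter) stays within the scatter. Compound 3 `Cn1cc(C(=O)c2ccc(F)cc2)cc1/C=C/C(=O)NO` differs from compound 2 by fluoro in place of nitro on an aromatic carbon. Within the data shown here, the only measured step at this carbon is a 1.6-fold higher number from compound 1 to compound 2 (0.21 log units; within the scatter), which was small. For compound 3 a step of a 1.5-fold lower number from compound 2 to compound 3 (0.17 log units; within the scatter) is therefore expected, that is no change beyond the scatter, with compound 3 estimated at 1600 nM and a range from 600 nM to 4500 nM.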

Compound 3, inhibition constant: 2290 nM
Estimate against measurement, compound 3: 1.4-fold (0.16 log units) below, and the stated range covers the measured number.
By their numbers in this assay, from the lowest: compounds 1, 3 and 2 (each within the scatter of the next).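

With fluoro on this aromatic carbon, para to a large group, all three substituents in this assay now lie within the scatter of one another (a 1.0-fold lower number from compound 2 to compound 3 (0.01 log units; within the scatter); a 1.6-fold higher number from compound 1 to compound 3 (0.20 log units; within the scatter)). Nitro, with three heavy atoms and two hydrogen-bond acceptors, thus gives way to fluoro, with one heavy atom and none, without a change beyond the scatter. No evidence is available to explain this result.

On these data alone, it remains open whether an amine or a carboxylic acid at this carbon would also stay within the scatter.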